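The compounds below may be only part of what the source reports. "The series", "measured", "known", "first", "only" and "open" are said of these compounds alone.

Working notes on the series.

Of the compounds shown here, two of this set carry numbers so far. Compound 1 `COc1cc(OC)c(OC)cc1CCC(=O)N1CCN(c2ccc(C(F)(F)F)cc2[C@@H](N)CC(C)C)CC1` gives 6100 nM in an assay on HEK293 cells for displacement of a labelled ligand from Melanocortin receptor 4 (Homo sapiens); on this read-out lower numbers stand for stronger inhibition and higher numbers for weaker inhibition. Compound 2 `CCC(C)[C@H](NCC1CCCO1)c1cc(C(F)(F)F)ccc1N1CCN(C(=O)CCc2ccc(Cl)cc2Cl)CC1` gives 780 nM in this assay, the lowest of the two numbers; the gap between compound 2 and compound 1 is beyond the usual scatter of repeated measurements, and both share the amide-linked piperazine attached to the trifluoromethyl-bearing ring, while differing in more than one place.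

Compound 3 `CC(C)C[C@H](NC(=O)CN)c1cc(C(F)(F)F)ccc1N1CCN(C(=O)CCc2ccc(Cl)cc2Cl)CC1` follows from compound 2 by a single change:

1-(((aminomethyl)carbonyl)amino)-3-methylbutyl in place of 2-methyl-1-(((oxolan-2-yl)methyl)amino)butyl on an aromatic carbon

The acyl part on the piperazine and the trifluoromethyl group stay as in compound 2. No measured pair in the set isolates this kind of change, so the direction of the step cannot be read from any shown step; the only anchor is the value of compound 2.

Expectation: compound 3 is estimated at 1500 nM in this assay, with a range from 300 nM to 8000 nM. This means an expected step of a 1.9-fold higher number from compound 2 to compound 3 (0.28 log units; within the scatter), a modest weakening that may or may not exceed the scatter, rather than a large move in either direction.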

Compound 3, inhibition constant: 19 nM
Estimate against measurement, compound 3: 79-fold (1.90 log units) above; measured number below the stated range.
By their numbers in this assay, from the lowest: compound 3; then compound 2; then compound 1.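

In this assay, the position on an aromatic carbon, ortho to a large group and meta to a trifluoromethyl group, proves highly sensitive to substitution: with the acyl part on the piperazine and the trifluoromethyl group held constant, placing 1-(((aminomethyl)carbonyl)amino)-3-methylbutyl in place of 2-methyl-1-(((oxolan-2-yl)methyl)amino)butyl gives a 41-fold lower number from compound 2 to compound 3 (1.61 log units; beyond the scatter). For the compounds shown here, this is the first step in the set confined to one place, and it shows that the five-membered non-aromatic ring is not needed for a low number here, since the entering group has no ring and fewer heavy atoms. Nothing available explains the size of this step.

The change alters the ring, the link to the side chain and the branching of the alkyl chain together, so the compounds shown leave open which of these features accounts for the step. Open comparisons are an acetyl group in place of the aminoacetyl group, which would test the terminal amine, and a 2-methylbutyl chain carrying the same aminoacetyl amide, which would separate the chain from the amide.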